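This account rests on a few compounds, and the source may have more. Where it says the series, first, only, none or still open, it means among the compounds named here.

Measured compounds:
- compound 1 `O=C(O)c1ccc(C(=O)/C(=C\c2ccc(F)c([N+](=O)[O-])c2)SCc2ccc(Cl)cc2)cc1`, 50000 nM
- compound 2 `COc1ccc(/C=C(/SCc2ccc(Cl)cc2)C(=O)c2ccc(Cl)cc2)cc1`, 10000 nM
- compound 3 `O=C(O)c1ccc(C(=O)/C(=C\c2ccc(Br)c([N+](=O)[O-])c2)SCc2ccc(Cl)cc2)cc1`, < 1000 nM

Compound 3 gives only a limit in a functional assay on DU-145 cells (Homo sapiens) for inhibition, read by trypan blue exclusion, with a stated time of 96 h (a higher number here means a weaker inhibitor of growth, a lower number a stronger inhibitor of growth), not a number: the limit of < 1000 nM in this assay, at which 1 of the 3 values shown sits, marks the point where it sits. On the numbers shown, compound 1 stands at the high end, and the single measured step, an at least 50-fold lower number from compound 1 to compound 3 (1.69 log units; beyond the scatter), shows how far a single change on the ring can carry the value.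

Compound 4 `COc1ccc(/C=C(/SCc2ccc(Cl)cc2)C(=O)c2ccc(C(=O)O)cc2)cc1` is the unmeasured compound. It differs from compound 3 in one place: 4-methoxyphenyl in place of 4-bromo-3-nitrophenyl on a double-bonded chain carbon bound to a double-bonded chain carbon.

Going by the values given here, no measured step concerns this exchange directly. The step from compound 1 to compound 3 swapped one group on that ring; here the whole 4-bromo-3-nitrophenyl ring is exchanged for 4-methoxyphenyl. Compound 2, which also carries 4-methoxyphenyl on the same chain carbon, gives 10000 nM in this assay. A weakening is therefore expected: an at least 10-fold higher number from compound 3 to compound 4 (1.00 log units; beyond the scatter). Compound 4 is estimated at 10000 nM, within 2000 nM to 50000 nM.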

Compound 4, concentration for 50% growth inhibition: 10000 nM
Compound 4: middle estimate and measured number agree at the digits printed; the range from low to high includes it.
By their numbers in this assay, from the lowest: compounds 2 and 4 (each within the scatter of the next); then compound 1. At a limit, below all of these: compound 3.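

In this assay, the same 4-methoxyphenyl on a double-bonded chain carbon moves the number in opposite directions depending on the ring it replaces: in place of 4-bromo-3-nitrophenyl it gives an at least 10-fold higher number from compound 3 to compound 4 (1.00 log units; beyond the scatter), and in place of 4-fluoro-3-nitrophenyl it gives a 5.0-fold lower number from compound 1 to compound 4 (0.70 log units; beyond the scatter). The first of these steps starts from compound 3, whose entry is a limit and not a number: the limit of < 1000 nM in this assay, at which 1 of the 4 values shown sits. With 4-methoxyphenyl in place, carboxy in place of chloro on an aromatic carbon gives no change at the digits printed from compound 2 to compound 4 (within the scatter), so this exchange shows no shift here.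

From the compounds shown here alone, it remains open whether the bromo group would keep the value of compound 3 without the nitro group, or how an amine would read in place of that nitro group. Also open, going by these compounds, is whether the carboxy-for-chloro exchange would stay as flat with a 4-bromo-3-nitrophenyl ring.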